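From a methylated ring to an ethoxy group

The source may report more compounds than this note shows. Statements on the series, on what has been measured and on what is new or still open speak of the compounds shown alone.

Values in a functional assay on K562 cells (Homo sapiens) for antiproliferative activity, read by MTT assay, with a stated time of 72 h (a higher number here means a weaker inhibitor, a lower number a stronger inhibitor), for the measured compounds

compound 1 `COc1cc(C(=O)c2sc3ccccc3c2-c2ccc(F)cc2)cc(OC)c1OC` with 2100 nM
compound 2 `COc1ccc(-c2c(C(=O)c3cc(OC)c(OC)c(OC)c3)sc3ccccc23)cc1` with 1700 nM
compound 3 `COc1ccc(-c2c(C(=O)c3cc(OC)c(OC)c(OC)c3)sc3ccccc23)cc1C` with > 10000 nM

Compound 3 sits at > 10000 nM as a limit of the assay and not a number. Compound 4 `CCOc1ccc(-c2c(C(=O)c3cc(OC)c(OC)c(OC)c3)sc3ccccc23)cc1` holds the same atoms as compound 3 joined differently. The difference is 4-ethoxyphenyl in place of 4-methoxy-3-methylphenyl on an aromatic carbon and it falls on an aromatic carbon of a five-membered aromatic ring with 1 sulfur, where 4-ethoxyphenyl takes the place of 4-methoxy-3-methylphenyl.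

The most telling measured step is an at least 5.8-fold higher number from compound 2 to compound 3 (0.76 log units; beyond the scatter) with methyl in place of hydrogen on an aromatic carbon. The step of an at least 4.7-fold higher number from compound 1 to compound 3 (0.67 log units; beyond the scatter) points the same way. By contrast, a 1.2-fold lower number from compound 1 to compound 2 (0.09 log units; within the scatter) shows that methoxy in place of fluoro made no difference beyond the scatter. Going by the values given here, the ring methyl of compound 3 is gone in compound 4, so the size of an at least 5.8-fold higher number from compound 2 to compound 3 (0.76 log units; beyond the scatter) suggests a return towards lower numbers, although no measured step covers an ethoxy group. The expected step is an at least 3.3-fold lower number from compound 3 to compound 4 (0.52 log units; beyond the scatter) by this estimate. The expected value for compound 4 is 3000 nM with an estimated range from 1000 nM to 9000 nM in this assay as the reading to be tested.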

Compound 4, half-maximal inhibitory concentration: 3100 nM
Compound 4: the middle estimate sits 1.0-fold (0.01 log units) below what was measured; the range from low to high includes it.
By their numbers in this assay, from the lowest: compounds 2, 1 and 4 (each within the scatter of the next). At a limit, above all of these: compound 3.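

In this assay, the step to the same atoms joined differently gives an at least 3.2-fold lower number from compound 3 to compound 4 (0.50 log units; beyond the scatter), so at this position on the five-membered ring the arrangement of the carbons matters, and their number alone does not decide the result. That step is only a minimum, because compound 3 rests on a limit of the assay and not on a number: the limit of > 10000 nM in this assay, at which 1 of the 4 values shown sits. Lengthening methoxy to ethoxy gives a 1.8-fold higher number from compound 2 to compound 4 (0.26 log units; within the scatter), and ethoxy in place of fluoro gives a 1.5-fold higher number from compound 1 to compound 4 (0.17 log units; within the scatter), so compound 1, compound 2 and compound 4 cannot be told apart, and among the four compounds only compound 3, with its ring methyl, stands out.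

The compounds shown leave open whether a longer chain such as propoxy, or an amine such as dimethylamino, in place of the ethoxy group would also stay level with these three compounds. On these data alone, they also leave open how far compound 3 lies past its limit, so the true size of the change that comes with its ring methyl remains unknown.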